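Swapping the amide for a pyridin-3-yl amine

A few compounds are considered here, and "the series" means these few. Any claim that something is new, unique, unknown or untested is made for them only; others in the source may bear on it.

Measured so far:
compound 1 `CC(O)c1ccc(C(=O)N[C@@H](C)Cn2ccc(-c3ccc(C#N)c(Cl)c3)n2)cc1`, 3690 nM
compound 2 `C[C@@H](Cn1ccc(-c2ccc(C#N)c(Cl)c2)n1)NC(=O)C1CC(=O)C1`, 3040 nM

Both were tested in a functional assay on LNCaP cells (Homo sapiens) for antiproliferative activity, read by CCK-8 assay, with a stated time of 6 days; a lower number here means a stronger inhibitor, a higher number a weaker inhibitor. Compound 2 gives the lower of the two numbers, though a 1.2-fold lower number from compound 1 to compound 2 (0.08 log units; within the scatter) lies within the scatter, so the two compounds are not distinguished. Compound 3 `C[C@@H](Cn1ccc(-c2ccc(C#N)c(Cl)c2)n1)Nc1cccnc1` is not yet measured; it differs from compound 2 by pyridin-3-yl in place of (3-oxocyclobutyl)carbonyl on an amine nitrogen. Among the compounds with values here, only the step from compound 1 to compound 2 bears on this, and it touched a different part of the molecule and was within the scatter, so the basis is thin. The expectation is a 1.2-fold higher number from compound 2 to compound 3 (0.06 log units; within the scatter), with no clear direction. Compound 3 is therefore estimated at 3500 nM, between 900 nM and 14000 nM.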

Compound 3, half-maximal inhibitory concentration: 430 nM
The estimate for compound 3 lay 8.1-fold (0.91 log units) above the measured number, and the stated range ends above it.
By their numbers in this assay, from the lowest: compound 3; then compounds 2 and 1 (each within the scatter of the next).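

In this assay, pyridin-3-yl in place of (3-oxocyclobutyl)carbonyl on this amine nitrogen gives a 7.1-fold lower number from compound 2 to compound 3 (0.85 log units; beyond the scatter), so the group at this position can shift the read-out beyond the scatter, which the earlier step on a carbonyl carbon did not show. This change removes the carbonyl and the four-membered ring together, so their contributions cannot be separated. No measurement here explains the drop in the number.

As far as these compounds go, whether the ring nitrogen of pyridin-3-yl matters remains open, and a plain phenyl on this amine nitrogen would test it. A pyridin-3-ylcarbonyl group on the same nitrogen would show whether losing the carbonyl matters.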